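This account rests on a few compounds, and the source may have more. Where it says the series, first, only, none or still open, it means among the compounds named here.

In an in vitro ADME assay on microsomes from liver (Mus musculus) for pharmacokinetics, read by LC-MS, with a stated time of 10 min, tested at 1 uM (on this read-out lower numbers stand for slow clearance and higher numbers for fast clearance), compound 1 `COc1ccc(NC(=O)[C@H]2CN(C)C[C@@H]2c2ccc(/C=C/C(=O)Nc3ccccc3N)cc2)cc1` gives 54 mL/min/kg and compound 2 `Cc1cccc(NC(=O)[C@H]2CN(C)C[C@@H]2c2ccc(/C=C/C(=O)Nc3ccccc3N)cc2)c1` gives 74 mL/min/kg on the same read-out. Compound 3 `CN1C[C@H](C(=O)Nc2ccc(F)c(F)c2)[C@@H](c2ccc(/C=C/C(=O)Nc3ccccc3N)cc2)C1` gives 46 mL/min/kg and stands within the scatter of both. Compound 4 `Cc1cc(NC(=O)[C@H]2CN(C)C[C@@H]2c2ccc(/C=C/C(=O)Nc3ccccc3N)cc2)ccc1Cl` carries 4-chloro-3-methylphenyl in place of 3,4-difluorophenyl on an amide-type nitrogen. Three measured steps change the group at that place: a 1.4-fold higher number from compound 1 to compound 2 (0.14 log units; within the scatter) and a 1.2-fold lower number from compound 1 to compound 3 (0.07 log units; within the scatter) and a 1.6-fold lower number from compound 2 to compound 3 (0.21 log units; within the scatter) all stay within the scatter. Within the data shown here, no measured compound carries the entering group, and compound 2 with 3-methylphenyl at 74 mL/min/kg is the nearest comparison. The expected result in this assay is a 1.3-fold higher number from compound 3 to compound 4 (0.13 log units; within the scatter) and so no step beyond the scatter. Compound 4 is estimated at 62 mL/min/kg with an expected range from 32 mL/min/kg to 105 mL/min/kg on this read-out.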

Compound 4, clearance: 65 mL/min/kg
Estimate against measurement, compound 4: 1.0-fold (0.02 log units) below; the measured number falls inside the stated range.
By their numbers in this assay, from the lowest: compounds 3, 1, 4 and 2 (each within the scatter of the next).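

In this assay chloro in place of hydrogen on an aromatic carbon gives a 1.1-fold lower number from compound 2 to compound 4 (0.06 log units; within the scatter) and thus adds a change within the 3-methylphenyl group to the earlier whole-group swaps. The further steps a 1.4-fold higher number from compound 3 to compound 4 (0.15 log units; within the scatter) and a 1.2-fold higher number from compound 1 to compound 4 (0.08 log units; within the scatter) also stay within the scatter, so no group at this amide-type nitrogen separates from another on this read-out. Nothing available bears on a cause for these numbers.

Still open, from the compounds shown here alone, is whether an aliphatic amine or a carboxylic acid in place of the substituted phenyl would give a step beyond the scatter. Also open, going by these compounds, is whether a longer chain between the amide-type nitrogen and the phenyl ring would do so.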